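Carbonyl substituent swap on the piperidine carbamate series

This account rests on a few compounds, and the source may have more. Where it says the series, first, only, none or still open, it means among the compounds named here.

Compound 3 `Cc1nc(S(C)(=O)=O)ccc1Oc1ncnc(OC2CCN(C(=O)SC3CC3)CC2)c1F` gives the lowest number of the three measured compounds in a functional assay on isolated protein for inhibition of Glucose-dependent insulinotropic receptor (Homo sapiens), read by HTRF and cAMP accumulation (on this read-out higher numbers stand for an effect only at larger amounts of compound and lower numbers for an effect already at smaller amounts), at 24.9 nM. Compound 1 `Cc1nc(S(C)(=O)=O)ccc1Oc1ncnc(OC2CCN(C(=O)OC(C)F)CC2)c1F` gives 65.5 nM and compound 2 `Cc1nc(S(C)(=O)=O)ccc1Oc1ncnc(OC2CCN(C(=O)O[C@@H](C)CF)CC2)c1F` gives 186 nM; the step of a 2.6-fold lower number from compound 1 to compound 3 (0.42 log units; beyond the scatter) and the larger step of a 7.5-fold lower number from compound 2 to compound 3 (0.87 log units; beyond the scatter) both favour the compound bearing the ring-containing group on the carbonyl carbon, while a 2.8-fold higher number from compound 1 to compound 2 (0.45 log units; beyond the scatter) shows the two open-chain groups differing modestly between themselves.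

Compound 4 `Cc1nc(S(C)(=O)=O)ccc1Oc1ncnc(OC2CCN(C(=O)C(C)(C)F)CC2)c1F` is not yet measured. Its change from compound 3 is a group of 4 heavy atoms (3 carbon, 1 fluorine; no ring) in place of a group of 4 heavy atoms (3 carbon, 1 sulfur; one three-membered non-aromatic ring of carbon only), on a carbonyl carbon. The two steps that bear on this are those from compounds 1 and 2 to compound 3, where an open-chain group with fluorine was replaced by the ring-containing group and the number fell modestly each time. Reversing that direction, though with a different open-chain group and no oxygen on the carbonyl carbon, the expected outcome in this assay is a modest rise for compound 4, a 2.4-fold higher number from compound 3 to compound 4 (0.38 log units; beyond the scatter), landing near compound 1. Compound 4 is therefore estimated at 60 nM, with a range from 25 nM to 150 nM.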

Compound 4, half-maximal effective concentration: 76.3 nM
Compound 4: middle estimate off by 1.3-fold (0.10 log units), on the low side; measured number inside the range.
By their numbers in this assay, from the lowest: compound 3; then compounds 1 and 4 (each within the scatter of the next); then compound 2.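

In this assay, a group with neither oxygen nor sulfur can stand on this carbonyl carbon without a loss against the open-chain oxygen groups: the 1-fluoro-1-methylethyl group gives a 1.2-fold higher number from compound 1 to compound 4 (0.07 log units; within the scatter), and a gain against the larger of those groups, with a 2.4-fold lower number from compound 2 to compound 4 (0.39 log units; beyond the scatter). The group with sulfur and the three-membered ring still holds the lowest number of the series, with a 3.1-fold higher number from compound 3 to compound 4 (0.49 log units; beyond the scatter), so the open-chain group without oxygen does not match it. No available measurement accounts for these steps.

The compounds shown change the sulfur and the three-membered ring together, so the share of each in that step remains open. On these data alone, how an isopropyl group, the same branched chain without fluorine, would compare on this carbonyl carbon also remains open.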